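Series notes: from compound 2 to compound 4

A few compounds are considered here, and "the series" means these few. Any claim that something is new, unique, unknown or untested is made for them only; others in the source may bear on it.

- compound 1 `COc1ccc(/C=C\c2cc(OC)c(OC)c(OC)c2)cc1NC(=O)[C@H](CO)NC(=O)[C@H](CCCNC(=N)N)NC(=O)[C@H](CCCCN)NC(=O)c1ccccc1`: 77900 nM
- compound 2 `COc1ccc(/C=C\c2cc(OC)c(OC)c(OC)c2)cc1NC(=O)[C@H](C)NC(=O)[C@H](CCCNC(=N)N)NC(=O)[C@H](CCCCN)NC(=O)c1ccccc1`: > 100000 nM
- compound 3 `COc1ccc(/C=C\c2cc(OC)c(OC)c(OC)c2)cc1NC(=O)CN`: 173000 nM

In an ADME assay on Huh-7 cells (Homo sapiens) for cytotoxicity, with a stated time of 24 h (on this read-out higher numbers stand for lower toxicity in this test and lower numbers for higher toxicity in this test), compound 2 gives > 100000 nM, which is a limit and not a number. That is the limit of > 100000 nM in this assay, at which 1 of the 3 values shown sits. The other two measured values are compound 1 at 77900 nM and compound 3 at 173000 nM.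

The next compound is compound 4 `COc1ccc(/C=C\c2cc(OC)c(OC)c(OC)c2)cc1NC(=O)[C@H](C)NC(=O)[C@H](CCCNC(=N)N)NC(=O)[C@H](CCCNC(=N)N)NC(=O)c1ccccc1`, which has not been measured. The change is a group of 4 heavy atoms (1 carbon, 3 nitrogen; no ring) in place of a group of 2 heavy atoms (1 carbon, 1 nitrogen; no ring), on a saturated chain carbon, four bonds along the chain from an amide-type nitrogen and a carbonyl carbon: a group of 4 heavy atoms in place of aminomethyl, on a saturated chain carbon, four bonds along the chain from an amide-type nitrogen and a carbonyl carbon.

For the measured compounds named here, no measured step covers this change. The nearest evidence is an at least 1.2-fold higher number from compound 1 to compound 2 (0.10 log units; that floor lies within the scatter), a replacement of hydroxy by hydrogen at a different place on the chain. Going by the values given here, with only that step to go on, no step beyond the scatter is expected in this assay, and no direction can be assigned. The assay may again report only a limit.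

This estimate means a step that the limit leaves unreadable from compound 2 to compound 4 as the expected step. The expected value for compound 4 is 110000 nM, with an estimated range of 55000 nM to 220000 nM.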

Compound 4, half-maximal cytotoxic concentration: 111000 nM
Compound 4: the middle estimate sits 1.0-fold (0.00 log units) below what was measured; measured number inside the range.
By their numbers in this assay, from the lowest: compounds 1, 4 and 3 (each within the scatter of the next, the first and the last beyond it).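

Compound 2 stands at a limit and not a number, so no step from compound 2 to compound 4 can be read in this assay: the limit of > 100000 nM in this assay, at which 1 of the 4 values shown sits.

The compounds shown leave open how far, and in which direction, the group of 4 heavy atoms in place of aminomethyl moves the half-maximal cytotoxic concentration in this assay.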